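The compounds below may be only part of what the source reports. "The series", "measured", "known", "first", "only" and "open" are said of these compounds alone.

Compound 1 `COc1ccnc(NC[C@@H]2C[C@@H](OCC(=O)NC[C@H](NC(=O)C3(C)CCCCC3)C(=O)O)CN2C(=O)OCc2ccccc2)c1` is measured in an assay on a protein complex for inhibition of integrin alpha-5/beta-1 (Homo sapiens), read by ELISA (on this read-out higher numbers stand for weaker inhibition and lower numbers for stronger inhibition), where compound 1 gives 0.8 nM. Of the two numbers at hand this is the lowest, and the nearest is compound 2 `COc1ccnc(NC[C@@H]2C[C@@H](OCC(=O)NC[C@H](NS(=O)(=O)c3c(C)cc(C)cc3C)C(=O)O)CN2C(=O)OCc2ccccc2)c1`, which in this assay gives 1.1 nM; the step of a 1.4-fold higher number from compound 1 to compound 2 (0.14 log units; within the scatter) lies within the scatter, so these two cannot be told apart. That step changes only the group on an amine nitrogen and leaves everything else as it is.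

Compound 3 `COc1ccnc(NC[C@@H]2C[C@@H](OCC(=O)NC[C@H](NC(=O)C3(C)CCCCC3)C(=O)O)CN2C(=O)CC(C)(C)C)c1` has not yet been measured in this assay. It differs from compound 1 at a different place: neopentyl in place of benzyloxy on a carbonyl carbon. Within the data shown here, no measured pair differs at this carbonyl carbon, so the single step seen so far does not speak to this change; it shows only that one exchange elsewhere in the molecule left the number within the scatter. With no direct evidence, the expected step from compound 1 to compound 3 is a 2.5-fold higher number from compound 1 to compound 3 (0.40 log units; beyond the scatter), a modest move toward weaker inhibition or none beyond the scatter. Compound 3 is therefore estimated to give 2 nM, with a range from 0.5 nM to 8 nM.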

Compound 3, half-maximal inhibitory concentration: 0.55 nM
Compound 3: middle estimate off by 3.6-fold (0.56 log units), on the high side, and the stated range covers the measured number.
By their numbers in this assay, from the lowest: compounds 3, 1 and 2 (each within the scatter of the next).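

At the carbonyl carbon on the amide-type ring nitrogen, benzyloxy can be exchanged for neopentyl with no change that can be told from the scatter in this assay (a 1.5-fold lower number from compound 1 to compound 3 (0.16 log units; within the scatter)). This exchange removes the six-membered aromatic ring and the hydrogen-bond acceptor of benzyloxy, so in this pair of compounds neither the ring nor that oxygen is required for a number in this low range, a point the earlier step on the amine nitrogen could not address. The data at hand offer no measurement that explains why the two groups read alike.

Going by these compounds, two groups at one position still give only a narrow view, so it remains open whether a longer chain, a simple methyl, or a chain ending in an amine or a carboxylic acid at this carbonyl carbon would keep the number in this assay within the same range. On these data alone, it also remains open whether neopentyl would read the same when combined with the (2,4,6-trimethylphenyl)sulfonyl group that compound 2 carries on the amine nitrogen.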